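A few compounds are considered here, and "the series" means these few. Any claim that something is new, unique, unknown or untested is made for them only; others in the source may bear on it.

For the measured compounds named here, compound 1, `Cc1ccc(S(=O)(=O)O[C@@H]2[C@@H](O)[C@H](n3cc(F)c(N)nc3=O)O[C@@H]2CO)cc1`, is the one member of this small set that gives a number in a functional assay on P815 cells (Mus musculus) for antiproliferative activity; a lower number here means a stronger inhibitor, a higher number a weaker inhibitor: compound 1 gives 3.9 ug/mL. Compound 2, `Nc1ccn([C@@H]2O[C@H](CO)[C@H](F)[C@H]2O)c(=O)n1`, reaches only a limit of the assay; in this assay compound 2 gives > 100 ug/mL. Compound 3, `Nc1ccn(C2OC(CO)C(Br)C2O)c(=O)n1`, likewise shows only a limit of the assay; in this assay compound 3 gives > 100 ug/mL. Compound 3 thus stands at the limit of > 100 ug/mL in this assay, at which 2 of the 3 values shown sit, and no number places it more exactly than that.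

Compound 4, `Nc1ccn(C2OC(CO)C(I)C2O)c(=O)n1`, has not yet been measured. It differs from compound 3 in a single place: iodo in place of bromo on a saturated ring carbon. Going by the values given here, no pair of measured compounds in this set differs in only one place, so the data offer no measured step from which the effect of such a swap could be read. The starting point is itself a limit, so any change would have to be large before it became visible at all. The expectation is therefore for no step beyond the scatter, and the estimated step is a step that the limit leaves unreadable from compound 3 to compound 4. Compound 4 is expected to give about 150 ug/mL. For compound 4 the estimate is unlikely to fall under 50 ug/mL. For compound 4 the estimate is unlikely to exceed 500 ug/mL.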

Compound 4, concentration for 50% inhibition: > 100 ug/mL
Compound 4: a limit, no number (the forecaster's own chance of this, stated with the estimate: 80%); the middle value lies beyond the limit too.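

Compound 3 and compound 4 each reach only a limit in this assay and give no number, so no step can be read for iodo in place of bromo: the limit of > 100 ug/mL in this assay, at which 3 of the 4 values shown sit.

The compounds shown leave open how strongly compound 3 and compound 4 really act, and whether this swap changes their activity at all.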